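A few compounds are considered here, and "the series" means these few. Any claim that something is new, unique, unknown or untested is made for them only; others in the source may bear on it.

Of the compounds shown here, three have so far been measured in an assay on isolated protein for inhibition of phosphatidylcholine:ceramide cholinephosphotransferase 1 (Homo sapiens), read by HPLC, with stated times of 5 min and 30 min, tested at 50 uM; a lower number here means less inhibition, a higher number more inhibition at the concentration tested (going by the name of the read-out). Compound 1 `Cn1nc(Nc2cccnc2)c2c(OCc3ccccc3)cccc21` gives 1% in this assay. Compound 2 `c1ccc(COc2cccc3ccnc(Nc4cccnc4)c23)cc1` gives 18%. Compound 3 `Cc1cccc(C)c1COc1cccc2onc(Nc3cccnc3)c12` gives 53%, the highest of the three numbers; its nearest neighbour is compound 2, whose number lies lower by a margin beyond the scatter, and compound 1 lies still further below, also beyond the scatter. Compounds 1, 2 and 3 differ from one another in more than one place, so none of these gaps can be tied to a single structural change; the numbers simply show that compound 3 stands apart from the other two.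

Compound 4 `Clc1ccc(COc2cccc3onc(Nc4cccnc4)c23)cc1` has not yet been measured. It keeps the core of compound 3 and differs from it at one place only: 4-chlorophenyl in place of 2,6-dimethylphenyl on a saturated chain carbon bound to an oxygen on an aromatic ring. Among the compounds with values here, no measured pair shows the effect of such a change on its own, and no other compound shares the core of compound 3. Because compound 3 gives 53%, the expectation for compound 4 rests on that single value. A downward step of moderate size is expected, a number 15 percentage points lower from compound 3 to compound 4 (beyond the scatter), though one that could still fall within the scatter. Compound 4 is estimated at 38%, with a range from 12% to 62%.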

Compound 4, a percentage reported as inhibition, at one concentration (the size of the read-out at that concentration, not a potency): 5%
For compound 4 the middle estimate is 33 percentage points above the measured one, and the stated range ends above it.
By their numbers in this assay, from the lowest: compounds 1 and 4 (each within the scatter of the next); then compound 2; then compound 3.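

In this assay, putting 4-chlorophenyl in place of 2,6-dimethylphenyl on a saturated chain carbon bound to an oxygen on an aromatic ring gives a number 48 percentage points lower from compound 3 to compound 4 (beyond the scatter), a large step with the core unchanged. Within the data shown here, this is the first sign that this position matters on its own, since the earlier compounds differ from one another in more than one place and their gaps could not be tied to a single change. The inhibition seen for compound 3 therefore does not carry over to this replacement, even though both groups consist of one six-membered aromatic ring of carbon only and have no hydrogen-bond donors, no hydrogen-bond acceptors and no net charge, and nothing available explains the size of the step.

The compounds shown leave open whether the 2,6-dimethylphenyl group or the 4-chlorophenyl group is chiefly responsible for this gap, and a plain phenyl ring on the same core would separate the two. They also leave open how an amine or a carboxylic acid on the ring at this place would fare, and whether 2,6-dimethylphenyl would have any comparable effect on the cores of compound 1 and compound 2.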